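Swapping the Amine on the Thiocarbonyl Carbon

The source may hold more compounds than are shown below. What is called first, only, known or untested is meant among the compounds shown, and "the series" means these compounds.

Measured so far in a functional assay on HEp-2 cells (Homo sapiens) for antiproliferative activity, read by MTT assay, with a stated time of 72 h; on this read-out higher numbers stand for weaker inhibition and lower numbers for stronger inhibition:
- compound 1 `O=c1c(CSC(=S)N2CCCC2)coc2ccccc12` gives 3600 nM
- compound 2 `COc1ccc2occ(CSC(=S)N3CCOCC3)c(=O)c2c1` gives 4800 nM
- compound 3 `CN1CCN(C(=S)SCc2coc3ccccc3c2=O)CC1` gives 2400 nM

Compound 3 has the lowest of the three numbers, but its nearest neighbour, compound 1, and even its furthest, compound 2, both lie within the scatter of it, so no ordering among the three can be claimed.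

Compound 4 `O=c1c(CSC(=S)N2CCOCC2)coc2ccccc12` is not yet measured. It differs from compound 3 in one place: morpholin-4-yl in place of 4-methylpiperazin-1-yl on a thiocarbonyl carbon. Among the compounds with values here, the only measured step that bears on this is the earlier swap of the amine on the same thiocarbonyl carbon, a 1.5-fold lower number from compound 1 to compound 3 (0.18 log units; within the scatter), which stayed within the scatter. Compound 2 also carries a morpholin-4-yl group but differs from compound 3 in a second place as well, so its value speaks only loosely; it and compound 3 are within the scatter of each other.

For compound 4 the expectation in this assay is therefore no shift beyond the scatter, perhaps a slightly higher number, an expected step of a 1.5-fold higher number from compound 3 to compound 4 (0.16 log units; within the scatter). Compound 4 is estimated at 3500 nM, with a likely range from 1700 nM to 7500 nM.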

Compound 4, half-maximal inhibitory concentration: 4400 nM
For compound 4 the middle estimate is 1.3-fold (0.10 log units) below the measured one; low and high end bracket the measured number.
By their numbers in this assay, from the lowest: compounds 3, 1, 4 and 2 (each within the scatter of the next).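

In this assay, the morpholin-4-yl group on the thiocarbonyl carbon can now be compared directly with both other amine groups: replacing 4-methylpiperazin-1-yl gives a 1.8-fold higher number from compound 3 to compound 4 (0.26 log units; within the scatter) and replacing pyrrolidin-1-yl gives a 1.2-fold higher number from compound 1 to compound 4 (0.09 log units; within the scatter) so all three single swaps at this position now stay inside the scatter and the three groups cannot be ranked. Within the data shown here, compound 4 also isolates the methoxy group for the first time, since hydrogen in place of methoxy on an aromatic carbon gives a 1.1-fold lower number from compound 2 to compound 4 (0.04 log units; within the scatter) and this change, made away from the amine, cannot be told from no change either. No separate measurement bears on why these values lie so close together.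

The amine groups shown are all rings, so it remains open whether an open-chain group such as dimethylamino or diethylamino on the thiocarbonyl carbon would produce a step beyond the scatter. The methoxy swap has also been read only alongside morpholin-4-yl, which leaves open whether it would stay as small alongside pyrrolidin-1-yl or 4-methylpiperazin-1-yl.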